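Fluorophenyl thioether in place of dimethylphenyl on the cinnamamide

The source may hold more compounds than are shown below. What is called first, only, known or untested is meant among the compounds shown, and "the series" means these compounds.

Working notes on the series. Going by the values given here, compound 1 `Cc1cc(C)cc(SCc2ccc(/C=C/C(=O)Nc3ccccc3N)cc2)c1` gives 11.7% in a functional assay on HeLa cells (Homo sapiens) for inhibition, read by CCK-8 assay, with a stated time of 72 h, tested at 2 uM (on this read-out higher numbers stand for more inhibition of growth at the one concentration tested and lower numbers for less inhibition of growth), and stands lowest of the two numbers measured so far. Compound 2 `Nc1ccccc1NC(=O)c1ccc(CSc2cccc(F)c2)cc1` gives 22.5% in this assay, a number beyond the scatter above compound 1. Compound 3 `Nc1ccccc1NC(=O)/C=C/c1ccc(CSc2ccc(F)cc2)cc1` is not yet measured; it differs from compound 1 by 4-fluorophenyl in place of 3,5-dimethylphenyl on a sulfur. Among the compounds with values here, no step between measured compounds carries this change, and compound 2 with its 22.5% holds a fluorophenyl on a different core. The change is expected to give a modest rise, a number 6.3 percentage points higher from compound 1 to compound 3 (within the scatter), at about the edge of the scatter. Compound 3 is expected to reach 18%, within 5% to 32%.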

Compound 3, percent growth inhibition at one concentration: 7.09%
Beside the measured number, compound 3's estimate is 10.9 percentage points above it; the range from low to high includes it.
By their numbers in this assay, from the lowest: compounds 3 and 1 (each within the scatter of the next); then compound 2.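

On the core of compound 1, 4-fluorophenyl in place of 3,5-dimethylphenyl on a sulfur gives a number 4.6 percentage points lower from compound 1 to compound 3 (within the scatter) in this assay. Going by these compounds alone, this is the first direct reading of this change, and it does not separate the two groups at this position. Nothing on hand bears on the reason for this step. Open, from the compounds shown here alone, is whether an amine or a carboxylic acid on that phenyl ring would take the number beyond the scatter of compound 1. Going by these compounds, a longer chain on the sulfur remains equally open.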